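Weak Inhibitors Sharing a Bis(trifluoromethyl)phenoxy Anilide Core

The compounds below may be only part of what the source reports. "The series", "measured", "known", "first", "only" and "open" are said of these compounds alone.

The series is characterised in an assay on HEK293 cells for inhibition of Toll-like receptor 8 (Homo sapiens), with a stated time of 16 h; on this read-out lower numbers stand for stronger inhibition and higher numbers for weaker inhibition. Among the compounds with values here, compound 1 `O=C(Nc1ccc(Oc2cc(C(F)(F)F)cc(C(F)(F)F)c2)cc1)c1c(F)cccc1Br` gives 6000 nM, the only number recorded in this assay. For compound 2 `O=C(Nc1ccc(Oc2cc(C(F)(F)F)cc(C(F)(F)F)c2)cc1)c1c(O)cccc1F` the result in this assay is "not determined" (no result reported), so it stands without a value. Compound 3 `O=C(Nc1ccc(Oc2cc(C(F)(F)F)cc(C(F)(F)F)c2)cc1)c1sccc1Cl` is not yet measured; it differs from compound 2 by 3-chlorothiophen-2-yl in place of 2-fluoro-6-hydroxyphenyl on a carbonyl carbon. With no value for compound 2, the size of the step from it cannot be gauged, and he would expect compound 3 to land near the weak level seen for compound 1 rather than beyond the scatter in either direction. Compound 3 is thus estimated at 5000 nM, within a range of 1000 nM to 30000 nM.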

Compound 3, half-maximal inhibitory concentration: 3200 nM
The estimate for compound 3 lay 1.6-fold (0.19 log units) above the measured number; measured number inside the range.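

In this assay, replacing 2-bromo-6-fluorophenyl with 3-chlorothiophen-2-yl on the carbonyl carbon gives a 1.9-fold lower number from compound 1 to compound 3 (0.27 log units; within the scatter), so this position accepts a five-membered aromatic ring in place of a six-membered one, with the inhibition remaining weak. The step from compound 2 cannot be read, as compound 2 has no value. Nothing available explains this result.

Going by these compounds, it remains open whether a ring bearing an amine or a carboxylic acid on this carbonyl carbon would move the number beyond the scatter, or whether any group here would give markedly stronger inhibition.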